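Imidazolyl in Place of Fluoro: Expected Effect on Inhibition

This account rests on a few compounds, and the source may have more. Where it says the series, first, only, none or still open, it means among the compounds named here.

Compound 1, `C[C@@H]1CN(c2ncccc2C(F)(F)F)CCN1C(=O)Nc1ccc(C(F)(F)F)cc1`: 17 nM
Compound 2, `CC(C)(C)c1ccc(NC(=O)c2ccc(-c3ncccc3F)cc2)cc1`: 3 nM

In a functional assay for antagonist activity at transient receptor potential cation channel subfamily V member 1 (Homo sapiens), read by FLIPR (on this read-out higher numbers stand for weaker inhibition and lower numbers for stronger inhibition), compound 2 gives the lowest of the two numbers, with compound 1 giving 17 nM, a gap beyond the usual scatter. Compound 3, `CC(C)(C)c1ccc(NC(=O)c2ccc(-c3ncccc3-c3ncc[nH]3)cc2)cc1`, has not yet been measured. It differs from compound 2 in one place: 1H-imidazol-2-yl in place of fluoro on an aromatic carbon. Going by the values given here, no measured pair shows a change of this kind, so its effect is uncertain. The step is expected to be modest and toward weaker inhibition, possibly no larger than the scatter: a 2.7-fold higher number from compound 2 to compound 3 (0.43 log units; beyond the scatter). Compound 3 is estimated at 8 nM, within a range from 2 nM to 40 nM.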

Compound 3, half-maximal inhibitory concentration: 3670 nM
For compound 3 the middle estimate is 460-fold (2.66 log units) below the measured one; the measured number lies above the stated range.
By their numbers in this assay, from the lowest: compound 2; then compound 1; then compound 3.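

In this assay, putting 1H-imidazol-2-yl in place of fluoro on this aromatic carbon, ortho to a large group and two atoms from the ring nitrogen, gives a 1200-fold higher number from compound 2 to compound 3 (3.09 log units; beyond the scatter), a large loss of inhibition. Going by these compounds alone, this shows that the position does not tolerate every group, which no earlier pair could show. Nothing available explains the size of this step.

Going by these compounds, it remains open whether a methyl group, a methoxy group or an amine on this carbon would keep inhibition close to that of compound 2, and whether a six-membered ring such as pyridyl would behave like 1H-imidazol-2-yl.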